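The source may report more compounds than this note shows. Statements on the series, on what has been measured and on what is new or still open speak of the compounds shown alone.

Measured compounds:
compound 1 `Cc1nn(C)c(Oc2ccc(Br)cc2)c1/C=N\CCCCCOc1cc2oc(=O)cc(C)c2cc1Cl` — 13800 nM
compound 2 `Cc1nn(C)c(Oc2ccc(I)cc2)c1/C=N\CCCCCOc1cc2oc(=O)cc(C)c2cc1Cl` — > 25000 nM
compound 3 `Cc1nn(C)c(Oc2ccc(Br)cc2)c1/C=N\CCCCCCOc1cc2oc(=O)cc(C)c2cc1Cl` — 4630 nM

The three were tested in a functional assay on HepG2 cells (Homo sapiens) for antiproliferative activity, read by MTT assay, with a stated time of 72 h; a higher number here means a weaker inhibitor, a lower number a stronger inhibitor. Compound 1 gives 13800 nM. For compound 2 the assay reports only a limit, > 25000 nM, and not a number. Compound 3 gives 4630 nM, the lowest of the two numbers; the difference between the core of compound 1 and the core of compound 3 is not broken down here.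

One change is seen once among the measured compounds: iodo in place of bromo on an aromatic carbon gives an at least 1.8-fold higher number from compound 1 to compound 2 (0.25 log units; that floor lies within the scatter). That step can only be given as a floor, because of the limit of > 25000 nM in this assay, at which 1 of the 3 values shown sits.

Compound 4 `Cc1nn(C)c(Oc2ccc(I)cc2)c1/C=N\CCCCCCOc1cc2oc(=O)cc(C)c2cc1Cl` has not been measured. It differs from compound 3 by iodo in place of bromo on an aromatic carbon, the same change in the same place as from compound 1 to compound 2. Compound 4 is therefore expected to show a 1.9-fold higher number from compound 3 to compound 4 (0.29 log units; within the scatter), a step resting on an at least 1.8-fold higher number from compound 1 to compound 2 (0.25 log units; that floor lies within the scatter), whose true size is not known. Compound 4 is estimated at 9000 nM, with a likely range from 4000 nM to 25000 nM.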

Compound 4, half-maximal inhibitory concentration: 14200 nM
Compound 4: the middle estimate sits 1.6-fold (0.20 log units) below what was measured; the range from low to high includes it.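

In this assay, iodo in place of bromo gives a 3.1-fold higher number from compound 3 to compound 4 (0.49 log units; beyond the scatter), a modest step that shows the change raising the number on the core of compound 3, and this does not conflict with the floor seen on the core of compound 1: the same change on two cores in this assay, an at least 1.8-fold higher number (0.25 log units; that floor lies within the scatter) from compound 1 to compound 2 and a 3.1-fold higher number (0.49 log units; beyond the scatter) from compound 3 to compound 4; the limit leaves it open whether they differ. Among the compounds shown here, what this does not show is that the change carries over from one core to the other with the same size, since only two pairs are at hand and only one of them gives a full step. As far as these compounds go, the true size of the step on the core of compound 1 stays unknown because compound 2 has only a limit and not a number: the limit of > 25000 nM in this assay, at which 1 of the 4 values shown sits.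

The compounds shown leave open how a chloro or fluoro group, or a plain hydrogen, would read at this same place on the phenoxy ring. They also leave open whether the change from bromo to iodo would give a similar step on a core with a longer chain than that of compound 4.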